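The source may hold more compounds than are shown below. What is called first, only, known or untested is meant among the compounds shown, and "the series" means these compounds.

Series notes, aryl group on the carbon with a double bond to nitrogen.

Compound 1 `COc1ccc(/C=N/NC(=O)Nc2ccc(Oc3ccnc(-c4nncn4CCN(C)C)c3)c(F)c2)c(OC)c1OC` is the reference point. In a functional assay on HT-29 cells (Homo sapiens) for cytotoxicity, read by MTT assay, with a stated time of 72 h (a higher number here means a weaker inhibitor, a lower number a stronger inhibitor), compound 1 gives 3970 nM. Compound 2 `CN(C)CCn1cnnc1-c1cc(Oc2ccc(NC(=O)N/N=C/c3ccc(O)cc3O)cc2F)ccn1` carries a 2,4-dihydroxyphenyl in place of the 2,3,4-trimethoxyphenyl; in this assay compound 2 gives 52600 nM. The step is a 13-fold higher number from compound 1 to compound 2 (1.12 log units; beyond the scatter). Among the measured compounds shown here, on the two numbers known so far compound 2 stands highest, with compound 1 its only neighbour.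

Compound 3 `Cc1cc(/C=N/NC(=O)Nc2ccc(Oc3ccnc(-c4nncn4CCN(C)C)c3)c(F)c2)cc(C)c1O` is not yet measured. It differs from compound 2 in one place: 4-hydroxy-3,5-dimethylphenyl in place of 2,4-dihydroxyphenyl on a carbon with a double bond to nitrogen. For the measured compounds named here, the only measured step that bears on this position is the one from compound 1 to compound 2, which was large, so a change of the aryl group at this place can move the number well beyond the scatter. The direction for compound 3 is not fixed by the data; compound 2 sits at the high end, and the entering group differs from the 2,4-dihydroxyphenyl that gave that high number, so a step back toward compound 1 is expected, though with a wide range. The expected step is a 4.4-fold lower number from compound 2 to compound 3 (0.64 log units; beyond the scatter). Compound 3 is estimated at 12000 nM, between 3000 nM and 50000 nM.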

Compound 3, half-maximal inhibitory concentration: 1220 nM
The estimate for compound 3 lay 9.8-fold (0.99 log units) above the measured number; the whole stated range lies above it.
By their numbers in this assay, from the lowest: compound 3; then compound 1; then compound 2.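

In this assay, the aryl group on the carbon with a double bond to nitrogen can now be seen to move the number down as well as up: the change to 4-hydroxy-3,5-dimethylphenyl gives a 43-fold lower number from compound 2 to compound 3 (1.63 log units; beyond the scatter), and it also passes the trimethoxy reference, with a 3.3-fold lower number from compound 1 to compound 3 (0.51 log units; beyond the scatter), so compound 3 has the lowest number of the three. A hydroxy group on the aryl ring therefore does not by itself go with a high number, since compound 3 carries one and compound 2, with its 2,4-dihydroxyphenyl, stands at the other end. Nothing measured in this set accounts for these steps.

The three aryl groups differ in several features at once, so the contributions of the two methyl groups and of the hydroxy pattern in compound 3 cannot be separated on these compounds. Also open, going by these compounds, is how a plain 4-hydroxyphenyl, a 3,5-dimethylphenyl without the hydroxy group, or an aryl group bearing an amine or a carboxylic acid would read at this place.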